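The compounds below may be only part of what the source reports. "The series", "measured", "known", "first", "only" and "open" are said of these compounds alone.

Going by the values given here, compound 1 `COc1cccc(-n2cc3nc(-c4cccnc4C)n(C[C@H]4CCCN(CC5CCO5)C4)c(=O)c3n2)c1` in an assay on HEK293 cells for displacement of a labelled ligand from growth hormone secretagogue receptor type 1 (Homo sapiens), with a stated time of 60 min (a lower number here means a stronger inhibitor, a higher number a weaker inhibitor), gives 23 nM, the higher of the two numbers measured so far. Compound 2 `CCO[C@@H](C)CN1CCC[C@H](Cn2c(-c3cccnc3C)nc3cn(-c4cccc(OC)c4)nc3c2=O)C1` gives 5 nM in this assay, and the step of a 4.6-fold lower number from compound 1 to compound 2 (0.66 log units; beyond the scatter) is the only measured one; it bears on the same place as the new change. Compound 3 `COc1cccc(-n2cc3nc(-c4cccnc4C)n(C[C@H]4CCCN(Cc5cnco5)C4)c(=O)c3n2)c1` differs from compound 1 by 1,3-oxazol-5-yl in place of oxetan-2-yl on a saturated chain carbon bound to an amine nitrogen in a ring. Among the compounds with values here, no measured step exchanges the oxetan-2-yl for an aromatic ring, so only a small step is expected here: the estimate is a 1.2-fold lower number from compound 1 to compound 3 (0.06 log units; within the scatter), within the scatter. Compound 3 is accordingly expected at 20 nM, with a range from 7 nM to 60 nM.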

Compound 3, half-maximal inhibitory concentration: 120 nM
Estimate against measurement, compound 3: 6.0-fold (0.78 log units) below; the whole stated range lies below it.
By their numbers in this assay, from the lowest: compound 2; then compound 1; then compound 3.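

On a saturated chain carbon bound to an amine nitrogen in a ring, an aromatic group now appears and the number rises (a 5.2-fold higher number from compound 1 to compound 3 (0.72 log units; beyond the scatter)) in this assay. The gap to the 1-ethoxyethyl group is wider still (a 24-fold higher number from compound 2 to compound 3 (1.38 log units; beyond the scatter)), so this place responds strongly to the group it carries, and both non-aromatic groups give lower numbers than 1,3-oxazol-5-yl. Nothing available explains the rise.

Still open, from the compounds shown here alone, is whether the rise goes with aromatic rings generally or with 1,3-oxazol-5-yl alone. A phenyl ring or a longer ether chain at the same place would help to separate these.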